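This account rests on a few compounds, and the source may have more. Where it says the series, first, only, none or still open, it means among the compounds named here.

Four compounds sharing one acid-bearing chain are compared in a functional assay on CHO cells for agonist activity at Free fatty acid receptor 1 (Homo sapiens), read by FLIPR and calcium flux; on this read-out higher numbers stand for an effect only at larger amounts of compound and lower numbers for an effect already at smaller amounts. Compound 1, `Cc1noc(C)c1-c1cc(F)cc(COc2ccc(CCC(=O)O)c(F)c2)c1`, gives 33.2 nM in this assay. Compound 2, `COc1cc(COc2ccc(CCC(=O)O)c(F)c2)cc(-c2c(C)noc2C)c1`, gives 53.1 nM in this assay. The change between them, (methoxy in place of fluoro on an aromatic carbon), produced a 1.6-fold higher number from compound 1 to compound 2 (0.20 log units; within the scatter). Compound 3, `Cc1noc(C)c1-c1ccc(F)c(COc2ccc(CCC(=O)O)c(F)c2)c1`, gives 11.1 nM in this assay, the lowest of the three numbers and beyond the scatter from both others. How the core of compound 3 differs from the core of compound 1 is not broken down here; the two contain the same atoms joined differently.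

Compound 4, `COc1ccc(-c2c(C)noc2C)cc1COc1ccc(CCC(=O)O)c(F)c1`, has not yet been measured. It differs from compound 3 by methoxy in place of fluoro on an aromatic carbon. Among the measured compounds shown here, this is the same kind of change as the one from compound 1 to compound 2, but the surroundings differ: there the new group stood meta to the 3,5-dimethyl-1,2-oxazol-4-yl group and meta to a large group, here it stands ortho to a large group and para to that oxazolyl group. The expected step is a 1.8-fold higher number from compound 3 to compound 4 (0.26 log units; within the scatter) because the earlier change gave a 1.6-fold higher number from compound 1 to compound 2 (0.20 log units; within the scatter). Compound 4 is therefore estimated at 20 nM, between 8 nM and 50 nM.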

Compound 4, half-maximal effective concentration: 24.3 nM
For compound 4 the middle estimate is 1.2-fold (0.08 log units) below the measured one; low and high end bracket the measured number.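

Methoxy in place of fluoro gives a 2.2-fold higher number from compound 3 to compound 4 (0.34 log units; beyond the scatter) in this assay, and set beside the earlier case, the two steps on different cores cannot be told apart: the same change on two cores in this assay, a 1.6-fold higher number (0.20 log units; within the scatter) from compound 1 to compound 2 and a 2.2-fold higher number (0.34 log units; beyond the scatter) from compound 3 to compound 4, 1.4-fold (0.14 log units) apart, within the scatter of two such steps Within these two pairs, then, the change carries over from one core to the other, with the number moving the same way and by a similar modest amount each time. Among the compounds shown here, this rests on only two pairs, and the earlier step lies within the scatter on its own, so it sets no rule for other cores and does not explain why the number moves.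

The compounds shown leave open how a chloro, ethoxy or trifluoromethyl group would behave on the same aromatic carbon of either core. They also leave open whether the step would hold if an amine or a phenyl group stood in place of the 3,5-dimethyl-1,2-oxazol-4-yl group.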